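Piperazine nitrogen substitution in a triaryl imidazole anilide series

The source may report more compounds than this note shows. Statements on the series, on what has been measured and on what is new or still open speak of the compounds shown alone.

Compound 1 `Cc1ccc2oc(SCC(=O)Nc3ccc(-c4nc(-c5ccccc5)c(-c5ccccc5)n4C)cc3)nc2c1` gives 1.1% in a functional assay on MCF7 cells (Homo sapiens) for cytotoxicity, read by MTT assay, with a stated time of 24 h, tested at 0.64 ug/mL; on this read-out lower numbers stand for a weaker effect and higher numbers for a stronger effect at the one concentration tested.
Compound 2 `Cn1cnnc1SCC(=O)Nc1ccc(-c2nc(-c3ccccc3)c(-c3ccccc3)n2C)cc1` gives 33.1% in this assay.
Compound 3 `CN1CCN(CC(=O)Nc2ccc(-c3nc(-c4ccccc4)c(-c4ccccc4)n3C)cc2)CC1` gives 1.1% in this assay.

Compound 3 stands level with compound 1 at the digits reported, and the two together are the lowest of the three numbers; the step of no change at the digits printed from compound 1 to compound 3 (within the scatter) lies within the scatter. Compound 2 is the only one set apart: the step of a number 32 percentage points lower from compound 2 to compound 3 (beyond the scatter) is large, as is a number 32 percentage points higher from compound 1 to compound 2 (beyond the scatter).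

Compound 4 `CN(C)/C=C/N1CCN(CC(=O)Nc2ccc(-c3nc(-c4ccccc4)c(-c4ccccc4)n3C)cc2)CC1` differs from compound 3 in one place: 2-(dimethylamino)ethenyl in place of methyl on an amine nitrogen in a ring. Among the compounds with values here, none of the measured steps touches this position. Within the data shown here, the steps of a number 32 percentage points higher from compound 1 to compound 2 (beyond the scatter) and a number 32 percentage points lower from compound 2 to compound 3 (beyond the scatter) both change the group on the chain carbon bound to the carbonyl, while the piperazine nitrogen substituent in compound 3 is varied by no measured pair. There is thus no direct precedent for the change, and no reason in the numbers to expect compound 4 to leave the low level of compound 3.

The step of a number 2.9 percentage points higher from compound 3 to compound 4 (within the scatter) is therefore expected to stay within the scatter. Compound 4 is estimated at 4% in this assay, with a range from 0% to 16%.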

Compound 4, a percentage reported as activity, at one concentration (the size of the read-out at that concentration, not a potency): 1.2%
Estimate against measurement, compound 4: 2.8 percentage points above, and the stated range covers the measured number.
By their numbers in this assay, from the lowest: compounds 1, 3 and 4 (each within the scatter of the next); then compound 2.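

In this assay, within the data shown here, this is the first read on the substituent at the ring amine nitrogen, and the step of a number 0.1 percentage points higher from compound 3 to compound 4 (within the scatter) lies within the scatter, so putting 2-(dimethylamino)ethenyl, with its 5 heavy atoms, double bond and hydrogen-bond acceptor, in place of methyl does not set compound 4 apart from compound 3. Among these compounds, the step of a number 0.1 percentage points higher from compound 1 to compound 4 (within the scatter) is also within the scatter, whereas the large step of a number 31.9 percentage points lower from compound 2 to compound 4 (beyond the scatter) shows that the longer piperazine substituent does not bring the piperazine series to the level of compound 2, which remains the only compound set apart. None of the information at hand explains why this substituent leaves the read-out at the level of compound 3.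

Going by these compounds, both piperazine compounds sit at the same low level, so it remains open whether any substituent on this nitrogen can raise the number, for example a free amine hydrogen, an acetyl group, a benzyl group or a longer alkyl chain. With one concentration and one cell line shown, it is also open whether compound 3 and compound 4 would separate at other concentrations or in other cells.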